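Swapping fluoro for iodo on the shared core

A few compounds are considered here, and "the series" means these few. Any claim that something is new, unique, unknown or untested is made for them only; others in the source may bear on it.

Measured in a functional assay with Cavia porcellus as the target; a lower number here means that less compound is needed, a higher number that more compound is needed for the effect:
- compound 1 `COC(=O)c1c(C)[nH]c(C)c1C(=O)c1ccccc1OC(=O)c1ccccc1O`: 3800 nM
- compound 2 `COC(=O)c1c(C)[nH]c(C)c1C(=O)c1ccccc1Br`: 8950 nM
- compound 3 `COC(=O)c1c(C)[nH]c(C)c1C(=O)c1ccccc1F`: 70000 nM

Compound 3, at 70000 nM, has the highest number of the three in this assay, so it needs the most compound for the effect. Compound 4 `COC(=O)c1c(C)[nH]c(C)c1C(=O)c1ccccc1I` has not yet been measured. It carries iodo in place of fluoro on an aromatic carbon.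

Within the data shown here, one measured step bears directly on this change: a 7.8-fold higher number from compound 2 to compound 3 (0.89 log units; beyond the scatter), with fluoro in place of bromo. That step is modest but beyond the scatter. Read in reverse, it suggests that replacing fluoro with a different halogen could lower the number, although no iodo compound has been measured. The expected change is a 9.3-fold lower number from compound 3 to compound 4 (0.97 log units; beyond the scatter), of similar size to that measured step and towards a lower number. This expectation rests on compound 2 at 8950 nM. Compound 4 is estimated at 7500 nM, with an expected range of 2500 nM to 22000 nM.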

Compound 4, half-maximal effective concentration: 5900 nM
Estimate against measurement, compound 4: 1.3-fold (0.10 log units) above; the range from low to high includes it.
By their numbers in this assay, from the lowest: compounds 1, 4 and 2 (each within the scatter of the next, the first and the last beyond it); then compound 3.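

In this assay, iodo in place of fluoro gives a 12-fold lower number from compound 3 to compound 4 (1.07 log units; beyond the scatter), so the drop seen earlier with bromo on this aromatic carbon, ortho to a large group, now has a second halogen behind it. Iodo in place of bromo gives a 1.5-fold lower number from compound 2 to compound 4 (0.18 log units; within the scatter), so these two halogens cannot be told apart in this assay, and among the three halogens shown only fluoro stands apart. Nothing available explains why fluoro differs from the other two halogens at this position.

As far as these compounds go, it remains open whether chloro would side with bromo and iodo or with fluoro. Also open, from the compounds shown here alone, is how a group of another kind, such as methoxy or an amine, would behave on the same aromatic carbon of the shared core.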